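This account rests on a few compounds, and the source may have more. Where it says the series, first, only, none or still open, it means among the compounds named here.

Measured so far in a functional assay on MCF7 cells (Homo sapiens) for antiproliferative activity; on this read-out lower numbers stand for stronger inhibition and higher numbers for weaker inhibition:
compound 1, `CC(=O)Oc1ccc(C(=O)Nc2cc3ccc(OCC4CCCN(C)C4)c(C)c3oc2=O)cc1CC=C(C)C`: 1650 nM
compound 2, `CC(C)=CCc1cc(C(=O)Nc2cc3ccc(OCCCNCC(C)C)c(C)c3oc2=O)ccc1O`: 1320 nM

Among the compounds with values here, only two values are in hand, and no step between them has been worked out; compound 2 and compound 1 give numbers within the scatter of each other, so no order between them can be read. Compound 3, `CC(C)=CCc1cc(C(=O)Nc2cc3ccc(OCCCN(C)c4ccccc4)c(C)c3oc2=O)ccc1O`, differs from compound 2 in one place: methyl(phenyl)amino in place of isobutylamino on a saturated chain carbon, three bonds along the chain from an oxygen on an aromatic ring. No comparable change has been measured in the series, so this change cannot be anchored to an observed effect. Compound 3 is expected to stay near compound 2, with a step of a 1.1-fold higher number from compound 2 to compound 3 (0.06 log units; within the scatter) in this assay, not beyond the scatter. The estimate for compound 3 is 1500 nM, within 500 nM to 5000 nM.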

Compound 3, half-maximal inhibitory concentration: > 50000 nM
Compound 3 was reported as a limit; the forecaster's own chance of this, stated with the estimate: 5%; at least 33-fold (1.52 log units) between middle value and limit.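

In this assay compound 3 gives > 50000 nM, which is a limit of the assay and not a number. The group on the propyl chain is therefore not indifferent: methyl(phenyl)amino in place of isobutylamino gives an at least 37-fold higher number from compound 2 to compound 3 (1.57 log units; beyond the scatter). The size of this step rests on a limit: the limit of > 50000 nM in this assay, at which 1 of the 3 values shown sits.

The change adds an aromatic ring and removes the hydrogen-bond donor together, and the compounds shown do not separate the two. Phenylamino, which keeps the ring and the donor, and methyl(isobutyl)amino, which has neither, would tell them apart on the same chain.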